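The source may hold more compounds than are shown below. What is called first, only, known or untested is meant among the compounds shown, and "the series" means these compounds.

Measured compounds in this series:

compound 1, `CC(C)=CCC1Cc2c(OCc3ccccc3)cc(=O)n(CCCO)c2CC1(C)C`: 11.1%
compound 2, `CC(C)=CCC1Cc2c(OCCCNC(=O)c3ccco3)cc(=O)n(CCCO)c2CC1(C)C`: 4.3%
compound 3, `CC(C)=CCC/C(C)=C/CC1Cc2c(OCc3ccccc3)cc(=O)n(CCCO)c2CC1(C)C`: 1.5%

All three numbers come from a functional assay on PANC-1 cells (Homo sapiens) for inhibition, read by MTT assay, with a stated time of 24 h, tested at 10 uM; on this read-out higher numbers stand for more inhibition at the one concentration tested (going by the name of the read-out) and lower numbers for less inhibition. Compound 3 sits alongside compound 2 and compound 1 with no separation beyond the scatter: the step of a number 9.6 percentage points lower from compound 1 to compound 3 (within the scatter) and the gap to compound 2 are both within the scatter, so the three compounds read as one group on this assay.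

Compound 4, `CC(C)=CCC/C(C)=C/CC1Cc2c(OC(=O)Nc3cccc(F)c3)cc(=O)n(CCCO)c2CC1(C)C`, keeps the chain of compound 3 and changes the group on the ring oxygen: (3-fluorophenyl)carbamoyl in place of benzyl on an oxygen on an aromatic ring. Among the compounds with values here, the only measured step that touches this oxygen is a number 6.8 percentage points lower from compound 1 to compound 2 (within the scatter), where the benzyl group was exchanged for a group of very different shape and the number hardly moved. The chain alteration a number 9.6 percentage points lower from compound 1 to compound 3 (within the scatter) was likewise within the scatter. Within the data shown here, no measured step in this set exceeds the scatter, so there is nothing in the data to suggest that exchanging benzyl for (3-fluorophenyl)carbamoyl should act otherwise.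

The step of a number 2.5 percentage points higher from compound 3 to compound 4 (within the scatter) is therefore expected to be small, with no direction beyond the scatter. Compound 4 is estimated at 4% in this assay, with a range from -6% to 15%.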

Compound 4, a percentage reported as inhibition, at one concentration (the size of the read-out at that concentration, not a potency): 0%
Beside the measured number, compound 4's estimate is 4 percentage points above it, within the range that was stated.
By their numbers in this assay, from the lowest: compounds 4, 3, 2 and 1 (each within the scatter of the next, the first and the last beyond it).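

On the oxygen on an aromatic ring, (3-fluorophenyl)carbamoyl in place of benzyl gives a number 1.5 percentage points lower from compound 3 to compound 4 (within the scatter) in this assay, which makes this the second exchange at this oxygen to stay within the scatter and the first on the chain of compound 3. The entering group adds a hydrogen-bond donor, a hydrogen-bond acceptor and a fluorine to the position, yet no gain in inhibition beyond the scatter appears, although compound 3 at 1.5% and compound 4 at 0% both sit so near the bottom of the read-out that this step can say little about any loss. Nothing available bears on why the number stays there.

From the compounds shown here alone, whether an amine or a carboxylic acid on this oxygen would move the number beyond the scatter remains open. Also open, going by these compounds, is whether (3-fluorophenyl)carbamoyl reads the same on the core of compound 1, without the added 3-methylbut-2-en-1-yl, where the starting number leaves more room for a drop to show.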